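A few compounds are considered here, and "the series" means these few. Any claim that something is new, unique, unknown or untested is made for them only; others in the source may bear on it.

In an assay (strain Wistar) for inhibition of Hormone-sensitive lipase (Rattus norvegicus), read by spectrophotometry (a lower number here means a stronger inhibitor, a higher number a weaker inhibitor), the measured compounds stand as follows:
Compound 1 `Cc1c(C(C)C)c(=O)on1C(=O)N1CCOCC1` gives 52 nM.
Compound 2 `CSc1nc(-c2ccc(Cl)cc2)nn1C(=O)N1CCCCC1` gives 1.76 nM.
Compound 3 `CSc1nc(-c2ccc(Cl)cc2)nn1C(=O)N(C)c1ccccc1` gives 2.82 nM.

Compound 3 holds the second highest of these three numbers. Its nearest neighbour is compound 2, and the step of a 1.6-fold higher number from compound 2 to compound 3 (0.20 log units; within the scatter) lies within the scatter; compound 1 is the furthest off, with a higher number beyond the scatter. Compound 4 `CCCCCCSc1nc(-c2ccc(Cl)cc2)nn1C(=O)N(C)c1ccccc1` differs from compound 3 by pentyl in place of hydrogen on a saturated chain carbon bound to a sulfur. Within the data shown here, the single measured step concerns the group on the carbonyl carbon and does not touch the chain on the sulfur, so no measured step bears on this change. For compound 4 a step of about a 1.8-fold higher number from compound 3 to compound 4 (0.25 log units; within the scatter) in this assay is expected, a small rise that may not exceed the scatter. Compound 4 is therefore estimated at 5 nM, with a range from 1 nM to 30 nM.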

Compound 4, half-maximal inhibitory concentration: 7.06 nM
Beside the measured number, compound 4's estimate is 1.4-fold (0.15 log units) below it, within the range that was stated.
By their numbers in this assay, from the lowest: compounds 2 and 3 (each within the scatter of the next); then compound 4; then compound 1.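

In this assay, going from methylsulfanyl to hexylsulfanyl gives a 2.5-fold higher number from compound 3 to compound 4 (0.40 log units; beyond the scatter), the first step shown at this position, so the chain on the sulfur does move the number, though only modestly. Even with the pentyl added, compound 4 keeps a low value of 7.06 nM. Nothing given here explains this rise.

On these data alone, what ethylsulfanyl, butylsulfanyl or a longer chain such as octylsulfanyl would give remains open, so a single step cannot show whether the number climbs steadily with length. Also open, as far as these compounds go, is whether the same change would give a step of similar size on compound 2, which carries piperidin-1-yl on the carbonyl carbon.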